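This account rests on a few compounds, and the source may have more. Where it says the series, first, only, none or still open, it means among the compounds named here.

Compound 1 `N/C(=N\O)c1ccc(S(=O)(=O)C2=C(c3ccccc3)OC(c3ccccc3)(c3ccccc3)C2)cc1` gives 37900 nM in an ADME assay on THP-1 cells (Homo sapiens) for cytotoxicity, read by flow cytometry, with a stated time of 72 h; a lower number here means a stronger inhibitor, a higher number a weaker inhibitor. Compound 2 `CC1(c2ccccc2)CC(S(=O)(=O)c2ccc(/C(N)=N/O)cc2)=C(c2ccccc2)O1` gives 54700 nM. Compound 3 `N/C(=N\O)c1ccc(Nc2ccc(S(=O)(=O)C3=C(c4ccc(/C(N)=N/O)cc4)OC(c4ccccc4)(c4ccccc4)C3)cc2)cc1` gives > 50000 nM, which is a limit of the assay and not a number.

Compound 1 holds the lowest of the two numbers; its nearest neighbour, compound 2, differs by a 1.4-fold higher number from compound 1 to compound 2 (0.16 log units; within the scatter), a step within the scatter. Compound 4 `N/C(=N\O)c1ccc(Nc2ccc(C3=C(S(=O)(=O)c4ccc(/C(N)=N/O)cc4)CC(c4ccccc4)(c4ccccc4)O3)cc2)cc1` arises from compound 1 by a group of 11 heavy atoms (7 carbon, 3 nitrogen, 1 oxygen; one six-membered aromatic ring of carbon only) in place of a hydrogen atom, on an aromatic carbon. Among the compounds with values here, no measured step follows this exact change; the only measured step, from compound 1 to compound 2, concerns a different change and stays within the scatter. Compound 3, which also carries this added group, sits at the limit of > 50000 nM in this assay, at which 1 of the 3 values shown sits. Compound 4 is therefore expected to give about 50000 nM, ranging from 20000 nM to 120000 nM, a step of a 1.3-fold higher number from compound 1 to compound 4 (0.12 log units; within the scatter), and it may itself be reported only as a limit.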

Compound 4, half-maximal inhibitory concentration: 48900 nM
The estimate for compound 4 lay 1.0-fold (0.01 log units) above the measured number, and the stated range covers the measured number.
By their numbers in this assay, from the lowest: compounds 1, 4 and 2 (each within the scatter of the next).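

In this assay, placing this group of 11 heavy atoms on an aromatic carbon, para to a large group, gives a 1.3-fold higher number from compound 1 to compound 4 (0.11 log units; within the scatter). At this position, a group this large therefore leaves the number within the scatter, and the change now has a measured size. Compound 3, which also carries the group, is a limit and not a number: the limit of > 50000 nM in this assay, at which 1 of the 4 values shown sits.

On these data alone, it remains open whether a smaller group at this aromatic carbon, such as an amine or a carboxylic acid, would also stay within the scatter.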